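The compounds below may be only part of what the source reports. "The series", "measured", "known", "first", "only" and "open" are said of these compounds alone.

Among the measured compounds shown here, compound 2 `O=C(CSc1nc2ccccc2s1)N/N=C/c1ccc(Oc2ccc3ccccc3c2)cc1` carries the higher of the two numbers measured so far in a physicochemical assay for lipophilicity, in phosphate buffer, measured as octanol-water partition, with a stated time of 24 h; a higher number here means a more lipophilic compound, a lower number a more polar compound; compound 2 gives 5.9, while compound 1 `Cc1cc(Oc2ccc(/C=N/NC(=O)CSc3nc4ccccc4s3)cc2)ccc1Cl` gives 5.7. For the measured compounds named here, the one measured step, a number 0.20 log units higher from compound 1 to compound 2 (within the scatter), swaps the ring on the aromatic oxygen. Compound 3 `O=C(CSc1nc2ccccc2s1)N/N=C/c1ccc(Oc2ccc([N+](=O)[O-])cc2)cc1` changes that same position again: 4-nitrophenyl in place of naphthalen-2-yl on an oxygen on an aromatic ring. Going by the values given here, no measured step tests this particular exchange, so the single known step is only a loose guide. The change is expected to lower the number beyond the scatter; compound 3 is estimated at 4.8, in a range from 4.2 to 5.5, a step of a number 1.10 log units lower from compound 2 to compound 3 (beyond the scatter).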

Compound 3, partition coefficient: 5.3
For compound 3 the middle estimate is 0.50 log units below the measured one, and the stated range covers the measured number.
By their numbers in this assay, from the lowest: compound 3; then compounds 1 and 2 (each within the scatter of the next).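

Putting 4-nitrophenyl on the aromatic oxygen shows that the ring at this position can shift the result in this assay: the step is a number 0.60 log units lower from compound 2 to compound 3 (beyond the scatter), and against the other ring it is a number 0.40 log units lower from compound 1 to compound 3 (beyond the scatter). The earlier exchange of 4-chloro-3-methylphenyl for naphthalen-2-yl showed no shift beyond the scatter. Nothing available explains this drop.

Still open, on these data alone, is whether a phenyl ring carrying an amine or a carboxylic acid on this oxygen would give a lower number than compound 3. A plain, unsubstituted phenyl ring would help show how much of the step belongs to the nitro group itself.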